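The compounds below may be only part of what the source reports. "The series", "measured", "known", "first", "only" and "open" are said of these compounds alone.

In a functional assay on A549 cells (Homo sapiens) for inhibition, read by MTT assay, with a stated time of 72 h (a lower number here means a stronger inhibitor, a higher number a weaker inhibitor), compound 1 (`CCCc1ccc(NC(=O)C2CCN(C/C=C/c3ccccc3)CC2)cc1`) gives 9470 nM. Compound 2 (`CCCCc1ccc(NC(=O)C2CCN(C/C=C/c3ccccc3)CC2)cc1`) gives 5910 nM, which amounts to a 1.6-fold lower number from compound 1 to compound 2 (0.20 log units; within the scatter). Compound 3 (`CCCCCc1ccc(NC(=O)C2CCN(C/C=C/c3ccccc3)CC2)cc1`) gives 3880 nM, and that is a 2.4-fold lower number from compound 1 to compound 3 (0.39 log units; beyond the scatter). The remaining measured step is a 1.5-fold lower number from compound 2 to compound 3 (0.18 log units; within the scatter). Compound 1 therefore stands level with compound 2 within the scatter, while only compound 3 is clearly apart from it.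

Compound 4 (`COc1ccccc1NC(=O)C1CCN(C/C=C/c2ccccc2)CC1`) has not yet been measured. Its change lies on the amide-type nitrogen, where 2-methoxyphenyl takes the place of 4-propylphenyl: 2-methoxyphenyl in place of 4-propylphenyl on an amide-type nitrogen. The measured steps only extend the saturated chain, so none of them tests this swap directly. The closest guide is the modest 2.4-fold lower number from compound 1 to compound 3 (0.39 log units; beyond the scatter), seen on lengthening a chain that compound 4 no longer carries. A move to a higher number in this assay is therefore expected, though with wide uncertainty. The expected step is a 1.5-fold higher number from compound 1 to compound 4 (0.17 log units; within the scatter). For compound 4 the estimated value is 14000 nM, with an expected range from 6000 nM to 35000 nM.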

Compound 4, half-maximal inhibitory concentration: > 100000 nM
Compound 4: no number, only a limit (the forecaster's own chance of this, stated with the estimate: 15%); at least 7.1-fold (0.85 log units) between middle value and limit.
By their numbers in this assay, from the lowest: compounds 3, 2 and 1 (each within the scatter of the next, the first and the last beyond it). At a limit, above all of these: compound 4.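

Compound 4 stands at a limit of the assay, not at a number: the limit of > 100000 nM in this assay, at which 1 of the 4 values shown sits. Putting 2-methoxyphenyl in place of 4-propylphenyl on the amide-type nitrogen gives an at least 10-fold higher number from compound 1 to compound 4 (1.02 log units; beyond the scatter), whereas the largest earlier change, in chain length alone, gave a 2.4-fold lower number from compound 1 to compound 3 (0.39 log units; beyond the scatter). In this assay, replacing the whole group on this nitrogen can therefore shift the result much further than the changes in chain length seen among compounds 1, 2 and 3.

This single swap removes the propyl chain and brings in a methoxy group at once, so the compounds shown cannot separate the two changes. A plain phenyl or a 4-methoxyphenyl on the same nitrogen would help to tell which of them matters.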